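Removing One Methyl from a Piperazine

This account rests on a few compounds, and the source may have more. Where it says the series, first, only, none or still open, it means among the compounds named here.

In a physicochemical assay for solubility (on this read-out higher numbers stand for higher solubility and lower numbers for lower solubility), compound 1 (`CN1CCN(c2cc(C(F)(F)F)ccc2[C@H]2CCOc3cc(S(=O)(=O)Nc4nccs4)ccc32)CC1`) gives 176000 nM as its reading. Going by the values given here, compound 2 (`Cc1nc(-c2cc(C(F)(F)F)ccc2[C@@H]2CCOc3cc(S(=O)(=O)Nc4nccs4)ccc32)co1`) gives 130000 nM as its reading, and these two numbers lie within the scatter of each other, so compound 1 sits level with the only other measured compound. Compound 3 (`O=S(=O)(Nc1nccs1)c1ccc2c(c1)OCC[C@@H]2c1ccc(C(F)(F)F)cc1N1CCNCC1`) has not yet been measured. Its difference from compound 1 is hydrogen in place of methyl on an amine nitrogen in a ring in counted form: hydrogen in place of methyl on an amine nitrogen in a ring, turning 4-methylpiperazin-1-yl into piperazin-1-yl. Among the compounds with values here, no two measured compounds differ in just one place, so the data give no direct guide to the size of this change. In this assay no step beyond the scatter is expected, in either direction. The expected size is a 1.1-fold higher number from compound 1 to compound 3 (0.03 log units; within the scatter) in this estimate. For compound 3 the estimated value is 190000 nM with an expected range from 75000 nM to 480000 nM around it.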

Compound 3, solubility: 288000 nM
Compound 3: the middle estimate sits 1.5-fold (0.18 log units) below what was measured; the range from low to high includes it.
By their numbers in this assay, from the lowest: compounds 2, 1 and 3 (each within the scatter of the next, the first and the last beyond it).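

In this assay, going by these compounds alone, putting hydrogen in place of the methyl on the amine nitrogen gives a 1.6-fold higher number from compound 1 to compound 3 (0.21 log units; within the scatter), the first direct reading of a single change in this set of compounds. At this position, then, 4-methylpiperazin-1-yl can become piperazin-1-yl without a step beyond the scatter, so this pair shows no clear difference in this assay. No independent measurement is available to explain this reading.

As far as these compounds go, this single pair says nothing about how far the position tolerates other groups, and whether an ethyl or an acetyl on the same nitrogen would also stay within the scatter remains open. Also open, from the compounds shown here alone, is whether a morpholine in place of the piperazine ring would keep the reading level with compound 1.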